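This account rests on a few compounds, and the source may have more. Where it says the series, first, only, none or still open, it means among the compounds named here.

Going by the values given here, in a physicochemical assay for lipophilicity (a lower number here means a more polar compound, a higher number a more lipophilic compound), compound 2 (`C=C(c1ccc2ccccc2c1)C1CCC2(CC1)COC(Nc1ccc(Cl)cc1)OO2`) stands at 6.15, the lower of the two values so far. Compound 1 (`C=C(c1cccc2ccccc12)C1CCC2(CC1)COC(Nc1cc(Cl)cc(Cl)c1)OO2`) gives 6.71, a gap beyond the scatter. Compound 3 (`C=C(c1ccc2ccccc2c1)C1CCC2(CC1)COC(Nc1cc(Cl)cc(Cl)c1)OO2`) comes from compound 2 by 3,5-dichlorophenyl in place of 4-chlorophenyl on an amine nitrogen, with 3,5-dichlorophenyl in place of 4-chlorophenyl on an amine nitrogen. Among the compounds with values here, no measured step isolates this change. Compound 1, at 6.71, also carries 3,5-dichlorophenyl on an amine nitrogen, so an upward move in this assay, beyond the scatter, is expected. The expected step is a number 0.55 log units higher from compound 2 to compound 3 (beyond the scatter). For compound 3 the estimate is 6.7, with an expected range of 6.4 to 7.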

Compound 3, partition coefficient: 6.71
Estimate against measurement, compound 3: 0.01 log units below, within the range that was stated.
By their numbers in this assay, from the lowest: compound 2; then compounds 1 and 3 (each within the scatter of the next).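

In this assay, the change from 4-chlorophenyl to 3,5-dichlorophenyl on the amine nitrogen now has a direct reading, a number 0.56 log units higher from compound 2 to compound 3 (beyond the scatter), with the rest of the structure held constant. Naphthalen-2-yl in place of naphthalen-1-yl on the double-bonded chain carbon gives no change at the digits printed from compound 1 to compound 3 (within the scatter), so these two attachments are not told apart in this assay. Nothing on hand bears on the reason for either step.

As far as these compounds go, whether the chlorine step carries over to the naphthalen-1-yl compounds remains open. So does the reading in this assay for an amine or a carboxylic acid on the phenyl ring.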